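Acylguanidine series: chain length and growth inhibition

This account rests on a few compounds, and the source may have more. Where it says the series, first, only, none or still open, it means among the compounds named here.

Measured compounds:
compound 1, `CC(C)=CC(=O)NC(=N)NC(=O)C=C(C)C`; in a functional assay on A549 cells (Homo sapiens) for inhibition, read by MTT assay, with a stated time of 72 h (on this read-out higher numbers stand for weaker inhibition of growth and lower numbers for stronger inhibition of growth), compound 1 gives 75600 nM
compound 2, `CC(C)=CCC/C(C)=C/C(=O)NC(=N)NC(=O)C=C(C)C`; in this assay compound 2 gives 37400 nM
compound 3, `CC(C)=CCC/C(C)=C/CC/C(C)=C/C(=O)NC(=N)NC(=O)/C=C(\C)CC/C=C(\C)CCC=C(C)C`; in this assay compound 3 gives 18500 nM

All three share the diacylguanidine core and differ only in the length of the unsaturated chains on either side. Compound 3 carries the longest chains and gives the lowest number of the three in this assay; compound 2 stands nearest to it and compound 1 furthest. The difference between the core of compound 3 and that of compound 2 is not broken down here, as the two differ in more than one place.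

One change is seen in a measured pair: hydrogen in place of 3-methylbut-2-en-1-yl on a saturated chain carbon bound to a double-bonded chain carbon. This gave a 2.0-fold higher number from compound 2 to compound 1 (0.31 log units; beyond the scatter), a modest step, yet beyond the scatter.

Compound 4, `CC(C)=CCC/C(C)=C/CC/C(C)=C/C(=O)NC(=N)NC(=O)/C=C(\C)CCC=C(C)C`, is not yet measured. It differs from compound 3 by the same change: hydrogen in place of 3-methylbut-2-en-1-yl on a saturated chain carbon bound to a double-bonded chain carbon. The place line is the same word for word in both pairs, so this is the same change, here made on a molecule whose other chain is longer.

Going by the values given here, on the one measured instance, the step from compound 3 to compound 4 in this assay is expected to be of similar size, a 1.7-fold higher number from compound 3 to compound 4 (0.24 log units; within the scatter), which rests on compound 2 and compound 1 giving a 2.0-fold higher number from compound 2 to compound 1 (0.31 log units; beyond the scatter). Among the compounds with values here, with only one prior instance, the range is kept wide. Compound 4 is therefore estimated at 32000 nM in this assay, between 18000 nM and 58000 nM.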

Compound 4, concentration for 50% growth inhibition: 38900 nM
The estimate for compound 4 lay 1.2-fold (0.08 log units) below the measured number; low and high end bracket the measured number.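

In this assay, putting hydrogen in place of 3-methylbut-2-en-1-yl on a saturated chain carbon bound to a double-bonded chain carbon gives a 2.1-fold higher number from compound 3 to compound 4 (0.32 log units; beyond the scatter), and the two instances of this change agree: the same change on two cores in this assay, a 2.0-fold higher number (0.31 log units; beyond the scatter) from compound 2 to compound 1 and a 2.1-fold higher number (0.32 log units; beyond the scatter) from compound 3 to compound 4, 1.0-fold (0.02 log units) apart, within the scatter of two such steps

The change therefore carries over between these two cores without a difference that can be read, but this rests on only two pairs in a single cell line and says nothing about cores beyond those shown. Putting 3,7-dimethylocta-2,6-dien-1-yl in place of hydrogen at the same kind of place gives a 1.0-fold higher number from compound 2 to compound 4 (0.02 log units; within the scatter), so adding chain length does not produce a readable step in every case, and this pair goes against any rule that a longer chain always gives a lower number.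

The compounds shown leave open how the change behaves when the unsaturated chain is replaced by a saturated alkyl chain of similar length, or by a chain ending in an amine or a carboxylic acid. Also open, from the compounds shown here alone, is whether a longer chain than those present here would continue the steps seen.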